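Series notes: methoxy in place of ethyl, compound 3 to compound 4

The source may hold more compounds than are shown below. What is called first, only, known or untested is meant among the compounds shown, and "the series" means these compounds.

Measured so far in a functional assay on Hep 3B2 cells (Homo sapiens) for antiproliferative activity, read by MTT assay, with a stated time of 24 h, tested at 0.05 ug/mL; a lower number here means a weaker effect, a higher number a stronger effect of the compound at the concentration tested:
compound 1 `CCc1ccc2nc(C(=O)Nc3c(F)cc(-c4cccc(F)c4)cc3F)c(C)c(O)c2c1`: 5.62%
compound 2 `Cc1c(C(=O)Nc2c(F)cc(-c3cccc(F)c3)cc2F)nc2ccc(OC(F)(F)F)cc2c1O`: 1.05%
compound 3 `CCc1ccc2nc(C(=O)Nc3c(F)cc(-c4cccc(F)c4)cc3F)c(C)c(C(=O)O)c2c1`: 0%

Compound 3 sits within the scatter of both compound 2 and compound 1; none of the three measured values is separated from another beyond the scatter. Compound 4 `COc1ccc2nc(C(=O)Nc3c(F)cc(-c4cccc(F)c4)cc3F)c(C)c(C(=O)O)c2c1` is not yet measured. It differs from compound 3 by methoxy in place of ethyl on an aromatic carbon. For the measured compounds named here, the one measured step at the same aromatic carbon, a number 4.6 percentage points lower from compound 1 to compound 2 (within the scatter), exchanged ethyl for trifluoromethoxy and stayed within the scatter; the other step, a number 5.6 percentage points lower from compound 1 to compound 3 (within the scatter), exchanged hydroxy for carboxy and likewise stayed within the scatter. Neither points to movement beyond the scatter in this assay, so for compound 4 the expected step is a number 1 percentage points higher from compound 3 to compound 4 (within the scatter). Compound 4 is estimated at 1% in this assay, in the range 0% to 8%.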

Compound 4, a percentage reported as inhibition, at one concentration (the size of the read-out at that concentration, not a potency): -0.66%
Beside the measured number, compound 4's estimate is 1.7 percentage points above it, outside the stated range (below it).
By their numbers in this assay, from the lowest: compounds 4, 3, 2 and 1 (each within the scatter of the next).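

In this assay, methoxy in place of ethyl on this aromatic carbon gives a number 0.7 percentage points lower from compound 3 to compound 4 (within the scatter). With carboxy held constant, the exchange keeps the count of heavy atoms, adds one hydrogen-bond acceptor and leaves the read-out within the scatter, so this position shows no sensitivity to the change here. No supporting data bear on why this is so. Still open, from the compounds shown here alone, is whether an amine or a longer chain on this aromatic carbon would give a step beyond the scatter. Also open, going by these compounds, is whether methoxy would behave alike with hydroxy in place of carboxy.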